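Trichlorophenyl amide extends the weakest member of a sulfonamide series

The source may report more compounds than this note shows. Statements on the series, on what has been measured and on what is new or still open speak of the compounds shown alone.

Compound 1, `Cc1ccc(S(=O)(=O)NCc2ccc(CNC(=O)c3ccc([N+](=O)[O-])cc3)cc2)cc1`: 10 nM
Compound 2, `Cc1ccc(S(=O)(=O)NCc2ccc(CNC(=O)c3ccc(F)cc3)cc2)cc1`: 1 nM
Compound 3, `Cc1ccc(S(=O)(=O)NCc2ccc(CNC(=O)c3ccccc3F)cc2)cc1`: 1000 nM

In an assay on MDA-MB-231 cells for binding affinity to C-X-C chemokine receptor type 4 (Homo sapiens), read by immunofluorescence and microscopy, with stated times of 10 min and 30 min (a higher number here means that more compound is needed for the effect, a lower number that less compound is needed), compound 3 carries the highest number of the three measured compounds. The step of a 100-fold higher number from compound 1 to compound 3 (2.00 log units; beyond the scatter) and the step of a 1000-fold higher number from compound 2 to compound 3 (3.00 log units; beyond the scatter) both lie beyond the scatter, so compound 3 is the least potent compound measured. The untested compound 4, `Cc1ccc(S(=O)(=O)NCc2ccc(CNC(=O)c3c(Cl)cc(Cl)cc3Cl)cc2)cc1`, differs from compound 3 in a single place: 2,4,6-trichlorophenyl in place of 2-fluorophenyl on a carbonyl carbon.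

For the measured compounds named here, no measured step exchanges one substituted phenyl of this kind for another carrying three halogens, so the only guidance is indirect. The steps of a 10-fold lower number from compound 1 to compound 2 (1.00 log units; beyond the scatter) and a 1000-fold higher number from compound 2 to compound 3 (3.00 log units; beyond the scatter) show that the substitution pattern of the aryl amide governs this assay strongly. Compound 4 keeps an aryl amide whose name, like that of compound 3, begins with a substituent in the same numbered place, and adds two more chlorines. The account therefore expects no step beyond the scatter, no change at the digits printed from compound 3 to compound 4 (within the scatter), with a wide range. For compound 4 the estimate in this assay is 1000 nM, between 200 nM and 5000 nM.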

Compound 4, effective concentration (reported as EC, without a stated level of effect): 10 nM
Beside the measured number, compound 4's estimate is 100-fold (2.00 log units) above it; measured number outside the range, below it.
By their numbers in this assay, from the lowest: compound 2; then compounds 1 and 4 (each within the scatter of the next); then compound 3.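

In this assay, the aryl group on this carbonyl carbon proves more forgiving than compound 3 suggested: exchanging 2-fluorophenyl for 2,4,6-trichlorophenyl gives a 100-fold lower number from compound 3 to compound 4 (2.00 log units; beyond the scatter) and so recovers most of what that fluorinated ring had lost. The bulkier halogenated ring also matches the nitro-bearing one, with no change at the digits printed from compound 1 to compound 4 (within the scatter) as its result, while a 10-fold higher number from compound 2 to compound 4 (1.00 log units; beyond the scatter) keeps 4-fluorophenyl as the group with the lowest number in the set. Nothing presented here accounts for this recovery.

The compounds shown leave open whether all three chlorines are needed, since a phenyl ring carrying only one or two chlorines would separate their contributions. They also leave open how a methoxy group or an amine on this ring would read in this assay and whether the sulfonamide half of the core would respond to changes.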